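Replacing Hydroxy with Amino in a Cytotoxic Series

A few compounds are considered here, and "the series" means these few. Any claim that something is new, unique, unknown or untested is made for them only; others in the source may bear on it.

In a functional assay on HeLa cells (Homo sapiens) for cytotoxicity, read by MTT assay (on this read-out lower numbers stand for stronger inhibition and higher numbers for weaker inhibition), compound 2 `COc1ccc(C#Cc2cc(OC)c(OC)c(OC)c2)cc1O` gives 1540 nM, the second highest of three numbers. Compound 3 `COc1ccc(C2CC2c2cc(OC)c(OC)c(OC)c2)cc1OP(=O)(O)O` stands lower at 370 nM, and compound 1 `COCOc1cc(C#Cc2cc(OC)c(OC)c(OC)c2)ccc1OC` stands higher at 26800 nM. Compound 4 `COc1ccc(C#Cc2cc(OC)c(OC)c(OC)c2)cc1N` differs from compound 2 in one place: amino in place of hydroxy on an aromatic carbon, ortho to a methoxy group. Among the compounds with values here, the only measured step at this place is a 17-fold lower number from compound 1 to compound 2 (1.24 log units; beyond the scatter), a large one, with hydrogen in place of methoxymethyl on the oxygen. Within the data shown here, that step leaves the oxygen in place, and no measured pair exchanges it for nitrogen, so it gives no direction here. The expected change is a 1.2-fold lower number from compound 2 to compound 4 (0.07 log units; within the scatter), with none beyond the scatter. For compound 4 the estimated value is 1300 nM, with an expected range from 300 nM to 5500 nM.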

Compound 4, half-maximal inhibitory concentration: > 30000 nM
Compound 4 gave a limit, no number (the forecaster's own chance of this, stated with the estimate: 3%); at least 23-fold (1.36 log units) between middle value and limit.
By their numbers in this assay, from the lowest: compound 3; then compound 2; then compound 1. At a limit, above all of these: compound 4.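

Compound 4 gave only a limit, not a number: the limit of > 30000 nM in this assay, at which 1 of the 4 values shown sits. Even so, an at least 19-fold higher number from compound 2 to compound 4 (1.28 log units; beyond the scatter) shows that this position does not tolerate every exchange, since amino in place of hydroxy leaves the counted hydrogen-bond donors and acceptors unchanged yet still gives a large step, whereas the earlier step only altered what sat on the oxygen. Against the other weak compound there is only a floor, an at least 1.1-fold higher number from compound 1 to compound 4 (0.04 log units; that floor lies within the scatter), so these two cannot be ordered.

Going by these compounds, whether a methylamino group, an acetamide or a fluorine on this aromatic carbon would stay close to compound 2 remains open. The compounds shown also do not say why amino differs so much from hydroxy here.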